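The compounds below may be only part of what the source reports. "The series", "measured", "known", "first", "only" and "open" are said of these compounds alone.

Measured compounds:

compound 1, `CC[C@@]1(c2ccccc2)OCC[C@@H](CCNCc2ccccc2)O1`: 20 nM
compound 2, `CC[C@]1(c2ccccc2)OCC[C@H](CCNCc2ccccc2)O1`: 28 nM
compound 3, `C[C@@]1(c2ccccc2)OCC[C@@H](CCN)O1`: > 10000 nM

In an assay on brain for displacement of a labelled ligand from Sigma non-opioid intracellular receptor 1 (Cavia porcellus) (on this read-out lower numbers stand for stronger inhibition and higher numbers for weaker inhibition), compound 1 gives 20 nM and stands lowest of the two numbers shown. Its nearest neighbour is compound 2, and the step of a 1.4-fold higher number from compound 1 to compound 2 (0.15 log units; within the scatter) lies within the scatter, which fits with the fact that compounds 1 and 2 differ only in the configuration as drawn. For compound 3 the value > 10000 nM is not a number but a limit of the assay; this is the limit of > 10000 nM in this assay, at which 1 of the 3 values shown sits.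

Compound 4, `c1ccc(CNCC[C@@H]2CCO[C@H](c3ccccc3)O2)cc1`, is not yet measured. It differs from compound 1 by hydrogen in place of ethyl on a saturated ring carbon. No measured step among the compounds shown touches this ethyl group: the only step, between compound 1 and compound 2, concerns configuration alone and was within the scatter. For compound 3 no single step to compound 1 is shown, as two places differ, so it only shows that a smaller group on this ring carbon together with a bare amine reaches the limit. The expected step of a 3.0-fold higher number from compound 1 to compound 4 (0.48 log units; beyond the scatter) is therefore a moderate weakening, weakly founded. For compound 4 the estimate is 60 nM with a range from 15 nM to 300 nM.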

Compound 4, inhibition constant: 6 nM
For compound 4 the middle estimate is 10-fold (1.00 log units) above the measured one, and the stated range ends above it.
By their numbers in this assay, from the lowest: compound 4; then compounds 1 and 2 (each within the scatter of the next). At a limit, above all of these: compound 3.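

In this assay the change on this saturated ring carbon gives a 3.3-fold lower number from compound 1 to compound 4 (0.52 log units; beyond the scatter), so the ethyl group is not needed for a low number here and a bare hydrogen does better. Until now every compound with the benzyl-bearing side chain carried ethyl at this place, and the only step shown changed configuration alone, so the effect of the group itself had not been seen. Nothing measured here gives a reason for this step.

From the compounds shown here alone, whether groups of other sizes at this place, such as propyl or a hydroxyl group, would follow ethyl or hydrogen stays open, as does the value of the mirror image of compound 4. Compound 3 sits at a limit of the assay, > 10000 nM, and differs from compound 1 in two places, so it cannot settle this.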